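A few compounds are considered here, and "the series" means these few. Any claim that something is new, unique, unknown or untested is made for them only; others in the source may bear on it.

Measured so far:
- compound 1, `O=C(COCc1ccccc1)N1CCN(c2cccc(Cl)c2)CC1`: 6700 nM
- compound 2, `O=C(COCc1ccccc1)N1CCN(c2ccc(F)cc2F)CC1`: 300 nM

In a functional assay on HEK293 cells for positive allosteric modulation of metabotropic glutamate receptor 5 (Homo sapiens), read by FLIPR and calcium flux (on this read-out higher numbers stand for an effect only at larger amounts of compound and lower numbers for an effect already at smaller amounts), compound 2 gives 300 nM, the lowest of the two numbers measured; its nearest neighbour is compound 1, which in this assay gives 6700 nM. Among the measured compounds shown here, the one measured step, a 22-fold lower number from compound 1 to compound 2 (1.35 log units; beyond the scatter), shows that the group on the amine nitrogen in the ring of the shared core governs the read-out strongly.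

Compound 3, `O=C(COCc1ccccc1)N1CCN(c2cc(Cl)ccn2)CC1`, has not yet been measured. It differs from compound 2 by 4-chloropyridin-2-yl in place of 2,4-difluorophenyl on an amine nitrogen in a ring. For the measured compounds named here, no measured pair shows an aromatic ring with a hetero atom at this place, so the only bearing step is the one from compound 1 to compound 2, which was large. Going by the values given here, because a 22-fold lower number from compound 1 to compound 2 (1.35 log units; beyond the scatter) moved the number so far on a change of this kind, a step of considerable size in this assay is expected here too, and its direction is uncertain; the account treats it as more likely upward than downward, since compound 2 already stands lowest. The step expected is a 5.0-fold higher number from compound 2 to compound 3 (0.70 log units; beyond the scatter), giving compound 3 an estimated 1500 nM, between 250 nM and 9000 nM.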

Compound 3, half-maximal effective concentration: 570 nM
Estimate against measurement, compound 3: 2.6-fold (0.42 log units) above; the measured number falls inside the stated range.
By their numbers in this assay, from the lowest: compounds 2 and 3 (each within the scatter of the next); then compound 1.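

In this assay, the step of a 1.9-fold higher number from compound 2 to compound 3 (0.28 log units; within the scatter) shows that an aromatic ring with a hetero atom can stand on the amine nitrogen in a ring without a change beyond the scatter, even though 4-chloropyridin-2-yl carries 1 hydrogen-bond acceptor and 2,4-difluorophenyl carries 0. The step of a 12-fold lower number from compound 1 to compound 3 (1.07 log units; beyond the scatter) is large, and since 3-chlorophenyl and 4-chloropyridin-2-yl both carry chlorine, the presence of chlorine alone does not set the number at this place, nor does a low number here depend on fluorine or on a ring of carbon only. No measurement at hand explains why compound 1 stands apart from compound 2 and compound 3.

The three compounds do not separate the effect of the ring nitrogen in 4-chloropyridin-2-yl from that of where its chlorine sits, so an unsubstituted pyridin-2-yl or a 3-chloropyridin-2-yl would be needed to tell these apart. On these data alone, it also remains open how an amine or a carboxylic acid on this aromatic ring would act, and whether a longer chain in place of the rest of the shared core would keep these numbers.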